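Phenyl for propyl on the chain of compound 2

This account rests on a few compounds, and the source may have more. Where it says the series, first, only, none or still open, it means among the compounds named here.

Measured in a functional assay on HBL-100 cells (Homo sapiens) for antiproliferative activity, read by sulforhodamine B assay, with a stated time of 48 h; a higher number here means a weaker inhibitor of growth, a lower number a stronger inhibitor of growth:
- compound 1 `CCOC(=O)C#CC(O/C=C/C(=O)OCC)C(C)C`: 3000 nM
- compound 2 `CCCCCC(C#CC(=O)OC)O/C=C/C(=O)OC`: 1900 nM
- compound 3 `CC1CCC(C(C)C)C(OC(=O)C#CC(O/C=C/C(=O)OC2CC(C)CCC2C(C)C)C(C)C)C1`: > 100000 nM, a limit of the assay and not a number

Compound 2 stands level with compound 1, as their two values lie within the scatter of each other. Compound 3 supplies only a limit, so it gives no number for comparison.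

Compound 4 `COC(=O)C#CC(CCc1ccccc1)O/C=C/C(=O)OC` has not yet been measured. Relative to compound 2, it carries phenyl in place of propyl on a saturated chain carbon, three bonds along the chain from an oxygen on an unsaturated carbon and a triple-bonded carbon.

For the measured compounds named here, no measured pair differs in one place only, so the size of this step in this assay has no direct precedent. No step beyond the scatter is expected, in either direction. The support is thin: compound 1 gives 3000 nM and compound 2 gives 1900 nM, within the scatter of each other although their side chains differ. The expected step of a 1.3-fold lower number from compound 2 to compound 4 (0.10 log units; within the scatter) therefore stays small. For compound 4 the estimated value is 1500 nM, with an expected range from 500 nM to 6000 nM.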

Compound 4, concentration for 50% growth inhibition: 2600 nM
Beside the measured number, compound 4's estimate is 1.7-fold (0.24 log units) below it; the measured number falls inside the stated range.
By their numbers in this assay, from the lowest: compounds 2, 4 and 1 (each within the scatter of the next). At a limit, above all of these: compound 3.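

In this assay the change of propyl to phenyl reads as a 1.4-fold higher number from compound 2 to compound 4 (0.14 log units; within the scatter) and gives the series its first step that differs in one place only. The saturated chain carbon, three bonds along the chain from an oxygen on an unsaturated carbon and a triple-bonded carbon, thus takes one six-membered aromatic ring of carbon only, with 6 heavy atoms entering where 3 leave, and no shift beyond the scatter follows, a tolerance that rests on this single pair. Nothing in the data at hand bears on the reason for this result.

Still open, going by these compounds, is whether an amine or a carboxylic acid at this place on the chain, or a longer chain carrying the phenyl, would stay level with compound 2 or move beyond the scatter. For the compounds shown here, also open is what the ester groups contribute on their own, since no measured pair changes only those while the chain stays fixed.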